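From Phenyl to Benzyl on the Oxygen

A few compounds are considered here, and "the series" means these few. Any claim that something is new, unique, unknown or untested is made for them only; others in the source may bear on it.

Values so far in a functional assay on brain (Rattus norvegicus, strain Wistar) for inhibition; a higher number here means a weaker inhibitor, a lower number a stronger inhibitor
Compound 1 `CCCCCCCOc1ccc(-c2c(C)[nH]c(=O)n2C)cc1` gives 5700 nM
Compound 2 `Cc1[nH]c(=O)n(C)c1-c1ccc(Oc2ccccc2)cc1` gives 8100 nM

Among the compounds with values here, only two values are known, and compound 2 (8100 nM) stands within the usual scatter of compound 1 (5700 nM), so the two cannot be told apart. Compound 3 (`Cc1[nH]c(=O)n(C)c1-c1ccc(OCc2ccccc2)cc1`) has not yet been measured. It carries benzyl in place of phenyl on an oxygen on an aromatic ring. Within the data shown here, one measured step bears on this change, because it altered the group on that same oxygen (a 1.4-fold higher number from compound 1 to compound 2 (0.15 log units; within the scatter)). There, phenyl replaced heptyl and the number stayed within the scatter. A single step is thin evidence, but it gives no reason to foresee a large shift. In this assay no step beyond the scatter, in either direction, is therefore expected (a 1.2-fold lower number from compound 2 to compound 3 (0.10 log units; within the scatter)). The estimate for compound 3 is 6500 nM (expected range 2500 nM to 16000 nM).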

Compound 3, half-maximal inhibitory concentration: 6700 nM
Compound 3: the middle estimate sits 1.0-fold (0.01 log units) below what was measured, and the stated range covers the measured number.
By their numbers in this assay, from the lowest: compounds 1, 3 and 2 (each within the scatter of the next).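

In this assay, benzyl in place of phenyl on the oxygen gives a 1.2-fold lower number from compound 2 to compound 3 (0.08 log units; within the scatter), so a ring joined to that oxygen through a chain carbon reads the same as a ring joined to it directly. The change that swaps the hexyl part of the chain for phenyl on that saturated carbon gives a 1.2-fold higher number from compound 1 to compound 3 (0.07 log units; within the scatter), which adds a second comparison with the long chain of compound 1 and likewise finds no separation. Heptyl, phenyl and benzyl on this oxygen therefore cannot be told apart here, and nothing measured explains why.

Going by these compounds, what remains open is whether any group on this oxygen can move the number beyond the scatter, for instance a small methyl, or a chain ending in an amine or a carboxylic acid. The compounds shown also leave open whether changes to the shared core would matter more than changes on this oxygen.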